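The source may report more compounds than this note shows. Statements on the series, on what has been measured and on what is new or still open speak of the compounds shown alone.

Measured in a functional assay on KB cells (Homo sapiens) for cytotoxicity; on this read-out lower numbers stand for an effect already at smaller amounts and higher numbers for an effect only at larger amounts of compound:
- compound 1 `Clc1ccc2c(N/N=C/c3ncc[nH]3)ccnc2c1`: 19.5 uM
- compound 2 `FC(F)(F)c1ccc(-c2n[nH]cc2/C=N/Nc2ccnc3cc(Cl)ccc23)cc1`: 1.2 uM
- compound 3 `Clc1ccc2c(N/N=C/c3ccc(CN4CCCC4)cc3)ccnc2c1`: 19.5 uM

Compound 1 reads level with compound 3, and both numbers lie well above that of compound 2. Compound 4 `Clc1ccc2c(N/N=C/c3ccco3)ccnc2c1` has not yet been measured. It carries furan-2-yl in place of 1H-imidazol-2-yl on a carbon with a double bond to nitrogen. Among the compounds with values here, no measured pair isolates this swap, so the guide is loose: compound 3 at 19.5 uM matches compound 1, while compound 2 at 1.2 uM shows that much lower numbers occur. In this assay a slight drop that stays within the scatter is expected, the estimated step being a 1.6-fold lower number from compound 1 to compound 4 (0.21 log units; within the scatter). For compound 4 the estimated value is 12 uM, with an expected range of 4 uM to 35 uM.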

Compound 4, concentration for half-maximal effect: 19.9 uM
The estimate for compound 4 lay 1.7-fold (0.22 log units) below the measured number; measured number inside the range.
By their numbers in this assay, from the lowest: compound 2; then compounds 1, 3 and 4 (each within the scatter of the next).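

In this assay, furan-2-yl in place of 1H-imidazol-2-yl on a carbon with a double bond to nitrogen gives a 1.0-fold higher number from compound 1 to compound 4 (0.01 log units; within the scatter). Within the data shown here, this is the first pair here that differs in one place only, and compound 1 and compound 4 read level even though the hydrogen-bond donor of 1H-imidazol-2-yl is absent from furan-2-yl. Nothing available explains this level reading. Still open, as far as these compounds go, is how a group without a five-membered aromatic ring, such as an open-chain amine or a carboxylic acid, would read at this position.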